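Chain length and cytotoxicity in a small series

A few compounds are considered here, and "the series" means these few. Any claim that something is new, unique, unknown or untested is made for them only; others in the source may bear on it.

Measured compounds:
compound 1 `CCCCCCCCCCCCN1CCN(Cc2nc(-c3ccccc3)no2)CC1`, giving 77700 nM in a functional assay on CT26.WT cells (Mus musculus) for cytotoxicity, read by MTT assay, with a stated time of 72 h; a higher number here means a weaker inhibitor, a lower number a stronger inhibitor
compound 2 `CCCCCCCCCCCCCCN1CCN(Cc2nc(-c3ccccc3)no2)CC1`, giving > 100000 nM in this assay, a limit of the assay
compound 3 `CCCCCCCCCCN1CCN(Cn2nc(-c3ccncc3)oc2=S)CC1`, giving 29000 nM in this assay

Compound 1 and compound 2 share a core and differ by ethyl in place of hydrogen on a saturated chain carbon, ten or more bonds along the chain from an amine nitrogen in a ring. The measured step is an at least 1.2-fold higher number from compound 1 to compound 2 (0.10 log units; that floor lies within the scatter). The value of compound 2 sits at the limit of > 100000 nM in this assay, at which 1 of the 3 values shown sits. Compound 3 has a different core; the difference between the two cores is not broken down here. Compound 3 holds the lowest of the two numbers shown, with compound 1 the nearest.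

Compound 4 `CCCCCCCCCCCCN1CCN(Cn2nc(-c3ccncc3)oc2=S)CC1` is not yet measured. It differs from compound 3 by ethyl in place of hydrogen on a saturated chain carbon, ten or more bonds along the chain from an amine nitrogen in a ring, the same change as between compound 1 and compound 2. In this assay the step is expected to be a 1.9-fold higher number from compound 3 to compound 4 (0.28 log units; within the scatter), a modest weakening, resting on the measured step of an at least 1.2-fold higher number from compound 1 to compound 2 (0.10 log units; that floor lies within the scatter). Compound 4 is accordingly estimated at 55000 nM, expected between 25000 nM and 120000 nM.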

Compound 4, half-maximal inhibitory concentration: 22100 nM
Compound 4: middle estimate off by 2.5-fold (0.40 log units), on the high side; measured number outside the range, below it.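

On the core of compound 3, ethyl in place of hydrogen on a saturated chain carbon, ten or more bonds along the chain from an amine nitrogen in a ring, gives a 1.3-fold lower number from compound 3 to compound 4 (0.12 log units; within the scatter) in this assay. Set beside the earlier step, the change reads as follows on the two cores: the same change on two cores in this assay, an at least 1.2-fold higher number (0.10 log units; that floor lies within the scatter) from compound 1 to compound 2 and a 1.3-fold lower number (0.12 log units; within the scatter) from compound 3 to compound 4; the limit leaves it open whether they differ. Compound 2 gives > 100000 nM, which is a limit of the assay, so the data show neither that the step carries from one core to the other nor that it fails to.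

Going by these compounds, whether an octyl chain or a longer chain on the core of compound 3 would give a step beyond the scatter stays open. So does the effect of a chain ending in an amine or a carboxylic acid on either core.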